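This account rests on a few compounds, and the source may have more. Where it says the series, first, only, none or still open, it means among the compounds named here.

Compound 1 `O=C(Nc1cccc(F)c1CN1C(=O)c2ccccc2C1=O)c1ccccn1` gives > 100000 nM in an assay on CHO cells for positive allosteric modulation of metabotropic glutamate receptor 5 (Homo sapiens), read by FLIPR; a higher number here means that more compound is needed for the effect, a lower number that less compound is needed; this is a limit of the assay, not a number.
Compound 2 `COc1ccccc1C(=O)Nc1ccc(Cl)cc1CN1C(=O)c2ccccc2C1=O` gives > 100000 nM in this assay; this too is a limit of the assay.
Compound 3 `O=C(/C=C/c1cc(Cl)ccc1NC(=O)c1ccccn1)c1ccccc1` gives 1700 nM in this assay.

Going by the values given here, compound 2 therefore stands at a limit rather than at a number: the assay reports only that more compound than it could test would be needed. It is not alone there, since (the limit of > 100000 nM in this assay, at which 2 of the 3 values shown sit). Among the compounds with values here, the only number among the three comes from compound 3, whose core is not that of compound 2, so nothing among the measured compounds links the two cores through a single change.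

Compound 4 `O=C(Nc1ccc(Cl)cc1CN1C(=O)c2ccccc2C1=O)c1ccccc1[N+](=O)[O-]` keeps the core of compound 2 and differs from it in one place: nitro in place of methoxy on an aromatic carbon. Within the data shown here, no measured pair shows what this exchange does in this assay, so the expectation rests on the limit of compound 2 alone. Compound 4 is expected to stay at or near that limit, with the step of a number no higher from compound 2 to compound 4 (the limit leaves the size open) expected to be none beyond the scatter. Compound 4 is estimated at 100000 nM, with a range from 20000 nM to 300000 nM, and a report of only a limit is the more likely outcome.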

Compound 4, half-maximal effective concentration: 5700 nM
Compound 4: middle estimate off by 18-fold (1.24 log units), on the high side; measured number outside the range, below it.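

In this assay, going by these compounds alone, nitro in place of methoxy on an aromatic carbon, ortho to a large group, gives an at least 17-fold lower number from compound 2 to compound 4 (1.24 log units; beyond the scatter), so this position can change the result even though the earlier compounds with phthalimide-free comparison were lacking.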